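The source may hold more compounds than are shown below. What is called first, only, known or untested is meant among the compounds shown, and "the series" means these compounds.

Measured so far:
compound 1 `Cc1cccc2c1CC/C2=C\C(=O)NC1CC1` — 15%
compound 2 `NC(=O)/C=C1\CCc2c(F)cccc21` — 40%
compound 3 `CNC(=O)/C=C1\CCc2ccc(Br)cc21` — 44%

These three were tested in a functional assay on the whole organism with Rattus norvegicus as the target, at a dose of 20 mg/kg by the oral route; on this read-out higher numbers stand for more inhibition at the one dose given (going by the name of the read-out) and lower numbers for less inhibition. Compound 3 gives the top number of the three, yet compound 2 cannot be told apart from it, as the gap between them lies within the usual scatter; compound 1 stands clearly lower. The next compound, compound 4 `CNC(=O)/C=C1\CCc2ccc(Cl)cc21`, differs from compound 3 in one place: chloro in place of bromo on an aromatic carbon. Whether this swap shifts the read-out is not shown by any measured pair here. Compound 4 is therefore expected to stay near compound 3, with a step no larger than the scatter: a number 4 percentage points lower from compound 3 to compound 4 (within the scatter). In this assay compound 4 is estimated at 40%, within a range from 20% to 60%.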

Compound 4, a percentage reported as inhibition, in the whole organism at one dose (the size of the read-out at that dose, not a potency): 0%
Beside the measured number, compound 4's estimate is 40 percentage points above it; measured number below the stated range.
By their numbers in this assay, from the lowest: compound 4; then compound 1; then compounds 2 and 3 (each within the scatter of the next).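

In this assay chloro in place of bromo, on an aromatic carbon meta to a fused ring and para to a fused ring, gives a number 44 percentage points lower from compound 3 to compound 4 (beyond the scatter) and so is no neutral exchange. Among these compounds, this is the first step that changes one place only, and it shows that the read-out at this position depends on which halogen sits there, even though each group is a single heavy atom.

As far as these compounds go, whether a methyl, methoxy or nitrile group on this carbon would stay near bromo or near chloro remains open. What lies behind the step also remains open, as no measurement shown here bears on it.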